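The compounds below may be only part of what the source reports. "The series", "measured", "known", "first", "only" and "open" are said of these compounds alone.

Measured compounds in a functional assay on HeLa cells (Homo sapiens) for cytotoxicity, read by MTT assay, with a stated time of 72 h, tested at 1 uM; on this read-out higher numbers stand for more inhibition of growth at the one concentration tested and lower numbers for less inhibition of growth:
- compound 1 `Cc1cccc(/C(N)=N/NC(=S)N2CCSCC2)n1` gives 46.5%
- compound 2 `Cc1cccc(/C(N)=N/NC(=S)N2CCOCC2)n1` gives 25.7%
- compound 3 `N/C(=N\NC(=S)N1CCSCC1)c1ccc(F)cn1` gives 19.6%

Compounds 1 and 2 share one core, and the change between them is morpholin-4-yl in place of thiomorpholin-4-yl on a thiocarbonyl carbon. In this assay this change produced a step of a number 20.8 percentage points lower from compound 1 to compound 2 (beyond the scatter). Compound 3 carries a different core; how the core of compound 3 differs from the core of compound 1 is not broken down here. Compound 3 gives a value that sits within the usual scatter of the value of compound 2, while the gap to compound 1 lies beyond the scatter.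

Compound 4 `N/C(=N\NC(=S)N1CCOCC1)c1ccc(F)cn1` has not yet been measured. It differs from compound 3 by morpholin-4-yl in place of thiomorpholin-4-yl on a thiocarbonyl carbon, the same change that turned compound 1 into compound 2, at the same kind of place. If the change works on the core of compound 3 as it did on the core of compound 1, the expected step from compound 3 to compound 4 in this assay is a number 13.6 percentage points lower from compound 3 to compound 4 (beyond the scatter), resting on the earlier step of a number 20.8 percentage points lower from compound 1 to compound 2 (beyond the scatter) and on the starting value of compound 3 of 19.6%, which leaves little room to fall further. Compound 4 is therefore expected to give about 6%, with a plausible range from -8% to 22%.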

Compound 4, percent growth inhibition at one concentration: 21.4%
Compound 4: middle estimate off by 15.4 percentage points, on the low side; measured number inside the range.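

In this assay, morpholin-4-yl in place of thiomorpholin-4-yl on a thiocarbonyl carbon gave a step of a number 1.8 percentage points higher from compound 3 to compound 4 (within the scatter), so on the core of compound 3 this change had no effect that can be told from the scatter. The change therefore did not carry over with the same size from one core to the other: the same change on two cores in this assay, a number 20.8 percentage points lower (beyond the scatter) from compound 1 to compound 2 and a number 1.8 percentage points higher (within the scatter) from compound 3 to compound 4, 22.6 percentage points apart, beyond the scatter of two such steps This shows that, in these two pairs, the outcome of the exchange depends on the core it sits on, but it does not show which feature of the cores is responsible, and two pairs read at a single concentration give no rule for any other core.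

On these data alone, it remains open how other groups on the thiocarbonyl carbon, such as piperidin-1-yl or 4-methylpiperazin-1-yl, would read on these two cores in this assay. As far as these compounds go, it also remains open whether the same exchange on further cores would follow compound 1 and compound 2, follow compound 3 and compound 4, or fall somewhere else, and whether the two steps would keep their difference at other concentrations.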